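The compounds below may be only part of what the source reports. "The series", "measured", "known", "first", "only" and "open" are said of these compounds alone.

Among the compounds with values here, in a functional assay on HepG2 cells (Homo sapiens) for inhibition, read by MTT assay, with a stated time of 48 h (on this read-out lower numbers stand for stronger inhibition and higher numbers for weaker inhibition), compound 1 (`COc1ccc(N(C)c2nc(C)nc3ccccc23)cc1C(=O)OCC[Se]C#N`) gives 890 nM and compound 2 (`COc1ccc(N(C)c2nc(C)nc3ccccc23)cc1C[Se]C#N`) gives 1110 nM, so compound 1 sits within the scatter of the only other measured number. Compound 3 (`COc1ccc(N(C)c2nc(C)nc3ccccc23)cc1C(=O)OCCCCCC[Se]C#N`) differs from compound 1 by a group of 7 heavy atoms (5 carbon, 1 nitrogen, 1 selenium; no ring) in place of a group of 3 heavy atoms (1 carbon, 1 nitrogen, 1 selenium; no ring), on a saturated chain carbon, two bonds along the chain from an oxygen next to a carbonyl group. Within the data shown here, the only measured step, a 1.2-fold higher number from compound 1 to compound 2 (0.10 log units; within the scatter), stayed within the scatter, and it does not test this change directly. No step beyond the scatter is therefore expected in this assay. The expected step is a 1.1-fold lower number from compound 1 to compound 3 (0.05 log units; within the scatter). For compound 3 the estimated value is 800 nM, with an expected range of 280 nM to 2500 nM.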

Compound 3, half-maximal inhibitory concentration: 2650 nM
For compound 3 the middle estimate is 3.3-fold (0.52 log units) below the measured one; measured number outside the range, above it.
By their numbers in this assay, from the lowest: compounds 1 and 2 (each within the scatter of the next); then compound 3.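

In this assay, the longer chain on the ester gives a 3.0-fold higher number from compound 1 to compound 3 (0.47 log units; beyond the scatter), which, unlike the earlier step at the aromatic carbon, lies beyond the scatter. The number at this saturated chain carbon therefore responds to chain length, in the direction of weaker inhibition, at least across these two chains. No available data bear on the cause of this step.

Two chain lengths do not define a trend, so a chain of intermediate length or a longer chain could fall anywhere. On these data alone, the effect of an amine or a carboxylic acid at the chain end also remains open.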